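The source may hold more compounds than are shown below. What is called first, only, known or untested is meant among the compounds shown, and "the series" means these compounds.

Measured compounds:
compound 1 `O=C(NNc1nc2ccccc2nc1Cc1ccccc1)c1ccc(Cl)cc1` — 34 nM
compound 2 `COc1ccc(C(=O)NNc2nc3ccccc3nc2Cc2ccccc2)cc1` — 86 nM
compound 3 `Cc1ccc(C(=O)NNC(=O)Cn2c(=O)c(Cc3ccccc3)nc3ccccc32)cc1` — 52 nM

All three numbers come from an assay for inhibition of Amine oxidase [flavin-containing] A (Bos taurus), read by fluorescence, with a stated time of 60 min; a higher number here means a weaker inhibitor, a lower number a stronger inhibitor. Compound 3 stands second highest of the three; its nearest neighbour is compound 1, whose number is lower, and its furthest is compound 2, whose number is higher, but both gaps lie within the usual scatter, so nothing separates compound 3 from either. Among the compounds with values here, the only step between compounds that differ in one place is a 2.5-fold higher number from compound 1 to compound 2 (0.40 log units; beyond the scatter), a methoxy in place of chloro on an aromatic carbon.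

Compound 4 `O=C(Cn1c(=O)c(Cc2ccccc2)nc2ccccc21)N/N=C/c1ccccc1` is not yet measured. It differs from compound 3 as follows: a group of 8 heavy atoms (7 carbon, 1 nitrogen; one six-membered aromatic ring of carbon only) in place of a group of 10 heavy atoms (8 carbon, 1 nitrogen, 1 oxygen; one six-membered aromatic ring of carbon only), on an amide-type nitrogen. The group that enters carries one double bond outside aromatic rings and one hydrogen-bond acceptor, and no hydrogen-bond donor remains in that part. Within the data shown here, no measured step touches this part of the series; the step from compound 1 to compound 2 sits on the outer ring and does not bear on it. With no comparable change in hand, the expectation rests on compound 3 alone, and a modest step in either direction, or none beyond the scatter, is the best that can be said. Compound 4 is therefore expected near 80 nM, within 25 nM to 300 nM, which would mean a 1.5-fold higher number from compound 3 to compound 4 (0.19 log units; within the scatter) from compound 3.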

Compound 4, half-maximal inhibitory concentration: 3.1 nM
Compound 4: middle estimate off by 26-fold (1.41 log units), on the high side; measured number outside the range, below it.
By their numbers in this assay, from the lowest: compound 4; then compounds 1, 3 and 2 (each within the scatter of the next, the first and the last beyond it).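

In this assay the amide-type nitrogen proves to be a place of large effect: the change there gives a 17-fold lower number from compound 3 to compound 4 (1.22 log units; beyond the scatter), a much bigger step than the modest 2.5-fold higher number from compound 1 to compound 2 (0.40 log units; beyond the scatter), which lies in another part of the molecule and told nothing about this one. The step bundles several differences, since ((4-methylphenyl)carbonyl)amino leaves with its methyl, its carbonyl and its hydrogen-bond donor, while the entering group has no hydrogen-bond donor and keeps one double bond outside aromatic rings, so no single difference can be credited with the lower number. No measurement in hand accounts for the step.

Still open, on these data alone, is which of these differences carries the step: a version of the entering group with a saturated amine linkage in place of its double bond would test that double bond, and one with the carbonyl kept but the methyl removed would test the methyl. Also open, as far as these compounds go, is whether chloro or methoxy on the aromatic ring of the entering group would move the number, and whether a pyridine ring could replace that ring without losing the gain.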